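Amide to urea on the methoxy series: an expectation

The source may report more compounds than this note shows. Statements on the series, on what has been measured and on what is new or still open speak of the compounds shown alone.

Compound 2 `COc1cc(-c2nn(-c3cccc(NC(=O)c4cccc(C(F)(F)F)c4)c3)cc2-c2ccncc2)ccc1Cl` carries an amide on the outer aromatic ring of the shared core. In a functional assay on SW-620 cells (Homo sapiens) for inhibition, read by sulforhodamine B assay, with a stated time of 48 h (a higher number here means that more compound is tolerated, a lower number that less compound is tolerated), compound 2 gives only a limit, > 50000 nM, so no number is fixed for it. Among the three values shown, one sits at the limit of > 50000 nM in this assay, at which 1 of the 3 values shown sits, and one at the limit (the limit of > 32500 nM in this assay, at which 1 of the 3 values shown sits); only compound 3 has a number.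

Compound 1 `O=C(Nc1cccc(-n2cc(-c3ccncc3)c(-c3ccc(Cl)c(O)c3)n2)c1)Nc1cccc(C(F)(F)F)c1` and compound 3 `O=C(Nc1cccc(-n2cc(-c3ccncc3)c(-c3ccc(Cl)c(O)c3)n2)c1)Nc1cc(C(F)(F)F)cc(C(F)(F)F)c1` are ureas on a hydroxy-bearing core. In this assay compound 1 gives only a limit, > 32500 nM. In this assay compound 3 gives 23400 nM. Among the measured compounds shown here, the one measured step, an at least 1.3-fold lower number from compound 1 to compound 3 (0.14 log units; that floor lies within the scatter), stays within the scatter.

Compound 4 `COc1cc(-c2nn(-c3cccc(NC(=O)Nc4ccc(Cl)c(C(F)(F)F)c4)c3)cc2-c2ccncc2)ccc1Cl` differs from compound 2 by (4-chloro-3-(trifluoromethyl)phenyl)amino in place of 3-(trifluoromethyl)phenyl on a carbonyl carbon. For the measured compounds named here, no measured step turns an amide into a urea, so the only guidance is that both ureas, compound 1 and compound 3, sit near the upper end of what the assay reports, as does compound 2 itself.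

Compound 4 is therefore expected to remain weak, with a step of an at least 1.4-fold lower number from compound 2 to compound 4 (0.15 log units; that floor lies within the scatter) that is not expected to leave the scatter, and an estimated value of 35000 nM spanning 12000 nM to 100000 nM in this assay.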

Compound 4, concentration lethal to 50% of the cells: > 32500 nM
Compound 4: no number, only a limit; the forecaster's own chance of this, stated with the estimate: 55%; the middle value lies beyond the limit too.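

Compound 2 and compound 4 each give only a limit in this assay, not a number, so the step between them cannot be read. The compounds shown leave open whether (4-chloro-3-(trifluoromethyl)phenyl)amino in place of 3-(trifluoromethyl)phenyl on a carbonyl carbon changes the result in this assay at all, and in which direction.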